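Ethoxy in place of chloro on the aryl hydrazone

This account rests on a few compounds, and the source may have more. Where it says the series, first, only, none or still open, it means among the compounds named here.

Compound 1 `CC1CC/C(=N\Nc2ccc(Cl)cc2)c2ncc(C(=O)O)c(=O)n21` has the highest of the three numbers in a functional assay on the whole organism for inhibition, with Rattus norvegicus as the target (a higher number here means that more compound is needed for the effect, a lower number that less compound is needed), giving 0.5 umol/kg. Compound 2 `CC1CC/C(=N\Nc2cccc(Br)c2)c2ncc(C(=O)O)c(=O)n21` gives 0.4 umol/kg, and compound 3 `CC1CC/C(=N\Nc2ccccc2O)c2ncc(C(=O)O)c(=O)n21` gives 0.26 umol/kg. The steps of a 1.3-fold lower number from compound 1 to compound 2 (0.10 log units; within the scatter) and a 1.9-fold lower number from compound 1 to compound 3 (0.28 log units; within the scatter) both stay within the scatter, as does a 1.5-fold lower number from compound 2 to compound 3 (0.19 log units; within the scatter), so the aryl changes seen so far have shifted the numbers little. Compound 4 `CCOc1ccc(N/N=C2\CCC(C)n3c2ncc(C(=O)O)c3=O)cc1` carries ethoxy in place of chloro on an aromatic carbon. For the measured compounds named here, no measured step swaps a group at this position, but because a 1.3-fold lower number from compound 1 to compound 2 (0.10 log units; within the scatter) and a 1.9-fold lower number from compound 1 to compound 3 (0.28 log units; within the scatter) were both small, the step of no change at the digits printed from compound 1 to compound 4 (within the scatter) is expected to stay within the scatter, in no particular direction. For compound 4 the estimate is therefore 0.5 umol/kg, with a range from 0.2 umol/kg to 1.2 umol/kg.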

Compound 4, dose for 50% inhibition: 1.6 umol/kg
Beside the measured number, compound 4's estimate is 3.2-fold (0.51 log units) below it; measured number above the stated range.
By their numbers in this assay, from the lowest: compounds 3, 2 and 1 (each within the scatter of the next); then compound 4.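

In this assay, ethoxy in place of chloro on an aromatic carbon, para to a large group, gives a 3.2-fold higher number from compound 1 to compound 4 (0.51 log units; beyond the scatter) and so is the first step among these compounds to lie beyond the scatter. For the compounds shown here, the aryl group therefore does not accept every change with as little shift as the earlier steps alone suggested. Nothing available explains this rise.

The compounds shown leave open whether methoxy or a longer propoxy chain at this place would give a number closer to that of compound 1 or compound 4. They also leave open how an amine there would compare.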